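From Methylphenyl to Fluoro-Methoxyphenyl on the Ring Nitrogen

The compounds below may be only part of what the source reports. "The series", "measured", "known", "first", "only" and "open" are said of these compounds alone.

Compound 3 `Cc1cccc(N2C(=O)CSC2c2cccc(C(=O)NCCCCc3ccccc3)c2)c1` stands highest of the three measured compounds in a functional assay on U2OS cells (Homo sapiens) for inhibition, read by CCK-8 assay, with a stated time of 72 h, tested at 1 uM (a higher number here means more inhibition at the concentration tested (going by the name of the read-out), a lower number less inhibition), giving 39%. Compound 2 `COc1ccccc1N1C(=O)CSC1C(=O)NCCCCc1ccccc1` gives 6% in this assay, and compound 1 `COc1ccc(OC)c(N2C(=O)CSC2c2cccc(C(=O)NCCCCc3ccccc3)c2)c1` gives 1%; both gaps to compound 3 lie beyond the scatter. Among the compounds with values here, the only single-point step among them, a number 38 percentage points higher from compound 1 to compound 3 (beyond the scatter), shows how strongly the group on the ring nitrogen matters. Compound 4 `COc1c(F)cccc1N1C(=O)CSC1c1cccc(C(=O)NCCCCc2ccccc2)c1` carries 3-fluoro-2-methoxyphenyl in place of 3-methylphenyl on an amide-type nitrogen in a ring. That step bears directly on this change, since the entering group again brings a methoxy group, as the 2,5-dimethoxyphenyl of compound 1 did, and compound 1 gave 1%. The expected result is a number 27 percentage points lower from compound 3 to compound 4 (beyond the scatter), a drop beyond the scatter. Compound 4 is estimated at 12%, between 0% and 35%.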

Compound 4, a percentage reported as inhibition, at one concentration (the size of the read-out at that concentration, not a potency): 12%
Beside the measured number, compound 4's estimate shows no gap at the digits printed; the measured number falls inside the stated range.
By their numbers in this assay, from the lowest: compounds 1, 2 and 4 (each within the scatter of the next, the first and the last beyond it); then compound 3.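

A methoxy group on the ring at this nitrogen is now seen in a second setting: 3-fluoro-2-methoxyphenyl sits well under 3-methylphenyl (a number 27 percentage points lower from compound 3 to compound 4 (beyond the scatter)), yet still above 2,5-dimethoxyphenyl (a number 11 percentage points higher from compound 1 to compound 4 (beyond the scatter)). So two methoxy-bearing rings at this position can be told apart, while neither approaches compound 3. Nothing measured here explains either step. Going by these compounds, whether the fluorine or the methoxy group drives the fall in compound 4 stays open. So does the effect of an aminophenyl group or a plain butyl chain on this nitrogen.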